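The compounds below may be only part of what the source reports. "The series", "measured", "known", "first", "only" and "open" are said of these compounds alone.

Compound 1 `CCCOC1=C(CCC)C(=O)/C(=C(O)/C=C/c2ccccc2)C(=O)C1(CCC)CCC`: 8.6 uM
Compound 2 `CCCCC1=C(OC)C(CCCC)(CCCC)C(=O)/C(=C(O)\C=C\c2ccccc2)C1=O`: 13 uM
Compound 3 `COC1=C(CC(C)C)C(=O)/C(=C(O)/C=C/c2ccccc2)C(=O)C1(CC(C)C)CC(C)C`: 12.4 uM

Of the compounds shown here, three that share a core have been measured in a functional assay on PC-3 cells (Homo sapiens) for antiproliferative activity, read by sulforhodamine B assay, with a stated time of 3 days; on this read-out lower numbers stand for an effect already at smaller amounts and higher numbers for an effect only at larger amounts of compound. Compound 1 gives 8.6 uM, compound 2 gives 13 uM and compound 3 gives 12.4 uM. Compound 1 has the lowest number of the three, but its nearest neighbour, compound 3, and its furthest, compound 2, both lie within the scatter of it, so the three cannot be placed in an order on these numbers.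

The next compound, compound 4 `CCCC1=C(OC)C(CCC)(CCC)C(=O)/C(=C(O)\C=C\c2ccccc2)C1=O`, has not yet been measured in this assay. It departs from compound 1 in one place: hydrogen in place of ethyl on a saturated chain carbon bound to an oxygen on an unsaturated carbon. Cut one bond further out, the same change reads propyl to methyl, or propoxy to methoxy, on the core. Among the compounds with values here, no measured pair shows this change on its own, so the step has to be judged from the spread of the three numbers, which is small. Compound 1 is expected to pass to compound 4 by a step of a 1.3-fold higher number from compound 1 to compound 4 (0.11 log units; within the scatter), a shift no larger than the scatter and, if anything, towards a higher number. Compound 4 is therefore estimated at 11 uM, within a range from 5 uM to 25 uM.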

Compound 4, concentration for half-maximal effect: 8.2 uM
Beside the measured number, compound 4's estimate is 1.3-fold (0.13 log units) above it; the measured number falls inside the stated range.
By their numbers in this assay, from the lowest: compounds 4, 1, 3 and 2 (each within the scatter of the next).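

In this assay, within the data shown here, the step of a 1.0-fold lower number from compound 1 to compound 4 (0.02 log units; within the scatter) gives the first direct reading of this change on the shared core. Among these compounds, no pair among the three earlier compounds differed in this one place alone. Putting hydrogen in place of ethyl on a saturated chain carbon bound to an oxygen on an unsaturated carbon, which reads as propoxy to methoxy, leaves the two compounds indistinguishable on this read-out, so for this pair the ethyl part of the propoxy group is not needed to keep the number where it stands. Nothing available explains why the number stays within the scatter across this change.

The compounds shown leave open whether this position tolerates a group of a different kind, such as a longer chain like hexyloxy, or a propoxy chain ending in an amine or a carboxylic acid. Going by these compounds, they also rest this reading on a single pair, so whether the change behaves in the same way on other versions of the core remains unknown.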